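Replacing the Aromatic Substituent with a Methyl Ester

The compounds below may be only part of what the source reports. "The series", "measured", "known", "first", "only" and "open" are said of these compounds alone.

Measured compounds:
Compound 1, `CCCCCCCCc1ccc(OCC(=O)Cn2nnc(-c3ccc(Cl)cc3)n2)cc1`, gives 35 nM in an assay on microsomes from brain for inhibition of Fatty-acid amide hydrolase 1 (Rattus norvegicus), read by fluorescence and HPLC, with a stated time of 60 min; a higher number here means a weaker inhibitor, a lower number a stronger inhibitor.
Compound 2, `CCCCCCCCc1ccc(OCC(=O)Cn2nnc(-c3ccccc3Cl)n2)cc1`, gives 32 nM in this assay.
Compound 3, `CCCCCCCCc1ccc(OCC(=O)Cn2nnc(-c3ccccn3)n2)cc1`, gives 18 nM in this assay.

Among these three, compound 3 has the lowest number, yet its nearest neighbour compound 2 is separated only by a 1.8-fold lower number from compound 2 to compound 3 (0.25 log units; within the scatter) and its furthest, compound 1, by a 1.9-fold lower number from compound 1 to compound 3 (0.29 log units; within the scatter), so no order among them can be claimed. The step from compound 1 to compound 2 is likewise a 1.1-fold lower number from compound 1 to compound 2 (0.04 log units; within the scatter).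

Compound 4, `CCCCCCCCc1ccc(OCC(=O)Cn2nnc(C(=O)OC)n2)cc1`, is not yet measured. It differs from compound 3 in one place: methoxycarbonyl in place of pyridin-2-yl on an aromatic carbon. The three measured steps all exchange one six-membered aromatic group for another on the same carbon, and all stay within the scatter. None of them replaces a ring with a group bearing no ring, so they bear on this change only loosely; they show that the carbon tolerates different aromatic groups without a shift beyond the scatter.

For compound 4 the expected step is a 3.3-fold higher number from compound 3 to compound 4 (0.52 log units; beyond the scatter), a modest rise with the direction not firmly settled. Compound 4 is therefore estimated at 60 nM in this assay, within 15 nM to 250 nM.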

Compound 4, half-maximal inhibitory concentration: 88 nM
For compound 4 the middle estimate is 1.5-fold (0.17 log units) below the measured one; the range from low to high includes it.
By their numbers in this assay, from the lowest: compounds 3, 2 and 1 (each within the scatter of the next); then compound 4.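

In this assay the carbon between two ring nitrogen atoms proves not indifferent to what it carries: the three aromatic groups could not be told apart, but methoxycarbonyl, which has no ring, gives a 4.9-fold higher number from compound 3 to compound 4 (0.69 log units; beyond the scatter) and also a 2.8-fold higher number from compound 2 to compound 4 (0.44 log units; beyond the scatter) and a 2.5-fold higher number from compound 1 to compound 4 (0.40 log units; beyond the scatter) as well. All three steps run the same way and lie beyond the scatter, so the tolerance seen among the aromatic groups does not extend to this group, although each step is only modest. No measurement shown accounts for this rise, and its origin stays unassigned.

Going by these compounds, whether the rise follows from losing the ring or belongs to the methoxycarbonyl itself remains open. Also open, on these data alone, is how a carboxylic acid, a primary amide or a plain methyl group on this carbon would read.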